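Bromo for Iodo: Expected Tolerance of Compound 4

The source may hold more compounds than are shown below. What is called first, only, known or untested is meant among the compounds shown, and "the series" means these compounds.

Compound 1 `O=C(/C=C/c1ccc([N+](=O)[O-])o1)c1ccc(C2CCCCC2)cc1` reaches only a limit, > 100000 nM, in an ADME assay on Vero cells (Chlorocebus sabaeus) for cytotoxicity, read by resazurin assay, with a stated time of 72 h; a lower number here means that less compound is tolerated, a higher number that more compound is tolerated.
Compound 2 `O=C(/C=C/c1ccc([N+](=O)[O-])s1)c1ccc(-n2ccnc2)cc1` gives 42700 nM in this assay.
Compound 3 `COc1ccc(/C=C/C(=O)c2cccc(I)c2)cc1` reaches only a limit, > 100000 nM, in this assay.

Compound 3 therefore stands not at a measured number but at the limit of this assay, the same limit reached by compound 1, so that (the limit of > 100000 nM in this assay, at which 2 of the 3 values shown sit). Only compound 2 yields a real number, and that number falls at a lower concentration than the limit where the other two sit.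

Compound 4 `COc1ccc(/C=C/C(=O)c2cccc(Br)c2)cc1` has not been measured. It differs from compound 3 in one place: bromo in place of iodo on an aromatic carbon. Going by the values given here, no measured pair in this set differs by such a change, so the expectation for compound 4 rests on the limit reached by compound 3 alone. The step from compound 3 to compound 4 in this assay is expected to be none beyond the usual scatter, written as a step that the limit leaves unreadable from compound 3 to compound 4. Compound 4 is thus estimated at 150000 nM, with a range from 50000 nM to 400000 nM, and most likely it too would be reported only as a limit.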

Compound 4, half-maximal cytotoxic concentration: > 100000 nM
Compound 4 ended at the assay's limit (the forecaster's own chance of this, stated with the estimate: 80%); the middle value does not contradict the limit.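

Compound 3 and compound 4 both sit at a limit of this assay, not at a measured number, so no step can be read between them: the limit of > 100000 nM in this assay, at which 3 of the 4 values shown sit.

The compounds shown leave open at what concentration either compound would become cytotoxic, and so whether bromo in place of iodo changes tolerance at all.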